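Swapping an Acetylphenyl for Benzyl on the Urea

A few compounds are considered here, and "the series" means these few. Any claim that something is new, unique, unknown or untested is made for them only; others in the source may bear on it.

Compound 2 `COC(=O)c1cc(=O)c2cc(NC(=O)Nc3cccc(C(C)=O)c3)ccc2[nH]1` and compound 1 `COC(=O)c1cc(=O)c2cc(NC(=O)Nc3ccc(F)c(Cl)c3)ccc2[nH]1` share one core and differ only in the group carried on an amide-type nitrogen. In an ADME assay on BJ cells (Homo sapiens) for antiproliferative activity, with a stated time of 72 h (on this read-out lower numbers stand for an effect already at smaller amounts and higher numbers for an effect only at larger amounts of compound), compound 1 reaches only a limit of the assay rather than a number, > 12600 nM. Compound 2 likewise reaches only a limit in this assay, > 16000 nM. The step that the two limits leave unreadable from compound 1 to compound 2 therefore cannot be read, since both of its ends sit at limits the limit of > 12600 nM in this assay, at which 1 of the 2 values shown sits, and (the limit of > 16000 nM in this assay, at which 1 of the 2 values shown sits). Compound 3 `COC(=O)c1cc(=O)c2cc(NC(=O)NCc3ccccc3)ccc2[nH]1` has not been measured yet; it alters compound 2 in one place: benzyl in place of 3-acetylphenyl on an amide-type nitrogen. Going by the values given here, no measured step bears on this change in a readable way, so no size can be drawn from the two compounds already tested. Compound 3 is expected to remain near a limit, an estimated step that the limit leaves unreadable from compound 2 to compound 3, with no direction beyond the scatter claimed. Compound 3 is therefore estimated at 20000 nM, within 8000 nM to 60000 nM.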

Compound 3, half-maximal effective concentration: > 19500 nM
Compound 3 ended at the assay's limit; the forecaster's own chance of this, stated with the estimate: 80%; the middle value is on the limit's open side.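

In this assay compound 3 also reaches only a limit, > 19500 nM. Its steps from compound 1 and compound 2 therefore cannot be read. The compounds shown leave open whether the group on the amide-type nitrogen changes the effect on these cells at all.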